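The source may report more compounds than this note shows. Statements on the series, on what has been measured and on what is new or still open speak of the compounds shown alone.

Measured compounds:
compound 2, `COc1cc(-c2nn(-c3cccc(NC(=O)Nc4ccc(Cl)c(Cl)c4)c3)cc2-c2ccncc2)ccc1Cl` — 5190 nM in a functional assay on NCI-H23 cells (Homo sapiens) for inhibition, read by sulforhodamine B assay, with a stated time of 48 h; a lower number here means a stronger inhibitor of growth, a higher number a weaker inhibitor of growth
compound 1, `O=C(Nc1cccc(-n2cc(-c3ccncc3)c(-c3ccc(Cl)c(O)c3)n2)c1)Nc1cccc(C(F)(F)F)c1` — > 32500 nM in this assay, a limit of the assay rather than a number

The account follows a single change. Compound 2 gives 5190 nM in this assay, and this is the only number shown. The other value in the series is a limit. Compound 1 reaches only the limit (the limit of > 32500 nM in this assay, at which 1 of the 2 values shown sits). Compound 3, `O=C(Nc1cccc(-n2cc(-c3ccncc3)c(-c3ccc(Cl)c(O)c3)n2)c1)Nc1ccc(Cl)c(Cl)c1`, has not yet been measured. It differs from compound 2 in one place: hydrogen in place of methyl on an oxygen on an aromatic ring. For the measured compounds named here, no step between measured compounds covers this change. Compound 1 carries the same hydroxy group as compound 3 and sits at the limit, though it also differs from compound 2 in its urea aryl, so it cannot be read as a clean guide. Compound 3 is expected to be weaker than compound 2, with a step of a 2.9-fold higher number from compound 2 to compound 3 (0.46 log units; beyond the scatter) that goes beyond the scatter. The estimate for compound 3 is 15000 nM, expected to fall between 5000 nM and 45000 nM.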

Compound 3, concentration for total growth inhibition: 29100 nM
Estimate against measurement, compound 3: 1.9-fold (0.29 log units) below, and the stated range covers the measured number.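

In this assay, the oxygen on the aromatic ring now has a measured pair: with 3,4-dichlorophenyl on the amide-type nitrogen, hydrogen in place of methyl gives a 5.6-fold higher number from compound 2 to compound 3 (0.75 log units; beyond the scatter), so the methoxy form is the stronger growth inhibitor of these two. Among the hydroxy compounds, 3,4-dichlorophenyl in place of 3-(trifluoromethyl)phenyl gives an at least 1.1-fold lower number from compound 1 to compound 3 (0.04 log units; that floor lies within the scatter), so this comparison shows no order between them. Compound 1 stays at a limit of the assay, not a number: the limit of > 32500 nM in this assay, at which 1 of the 3 values shown sits.

As far as these compounds go, this methoxy-to-hydroxy change is read on a single pair, so whether it holds with 3-(trifluoromethyl)phenyl on the amide-type nitrogen remains open. Also open, from the compounds shown here alone, is how an ethoxy group or an amine at this place on the ring would compare with the methoxy and hydroxy groups.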